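A few compounds are considered here, and "the series" means these few. Any claim that something is new, unique, unknown or untested is made for them only; others in the source may bear on it.

Measured compounds:
Compound 1, `CCCS(=O)(=O)Nc1ccc(F)c(C(=O)c2n[nH]c3ncc(-c4cccc(Cl)c4)cc23)c1F`: 40%
Compound 2, `CCCS(=O)(=O)Nc1ccc(F)c(C(=O)c2n[nH]c3ncc(-c4cccc(C)c4)cc23)c1F`: 15%
Compound 3, `CCCS(=O)(=O)Nc1ccc(F)c(C(=O)c2n[nH]c3ncc(-c4ccc(OC)cc4)cc23)c1F`: 4.2%

These numbers come from an assay for binding affinity to dual specificity mitogen-activated protein kinase kinase 4 (Homo sapiens), read by KINOMEscan, tested at 100 nM; on this read-out lower numbers stand for a stronger effect and higher numbers for a weaker effect at the one concentration tested. Compound 3 stands lowest of the three, with compound 2 nearest and compound 1 furthest, both gaps beyond the scatter. Compound 4 `CCCS(=O)(=O)Nc1ccc(F)c(C(=O)c2n[nH]c3ncc(-c4cccc(N(C)C)c4)cc23)c1F` has not yet been measured. It differs from compound 3 in one place: 3-(dimethylamino)phenyl in place of 4-methoxyphenyl on an aromatic carbon. Within the data shown here, three measured steps bear on this change. Both moves onto 4-methoxyphenyl lowered the number, a number 35.8 percentage points lower from compound 1 to compound 3 (beyond the scatter) and a number 10.8 percentage points lower from compound 2 to compound 3 (beyond the scatter), while the exchange of one substituted phenyl for another of the same substitution pattern gave a number 25 percentage points lower from compound 1 to compound 2 (beyond the scatter). Compound 4, like compound 1 and compound 2, carries a phenyl other than 4-methoxyphenyl, so the number is expected to move back upward from compound 3, by roughly the size of the smaller of the two steps that led to compound 3. The expected step is a number 10.8 percentage points higher from compound 3 to compound 4 (beyond the scatter). Compound 4 is therefore estimated at 15%, with a range from 4% to 40%.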

Compound 4, a percentage reported as activity, at one concentration (the size of the read-out at that concentration, not a potency): 26%
Estimate against measurement, compound 4: 11 percentage points below; the range from low to high includes it.
By their numbers in this assay, from the lowest: compound 3; then compound 2; then compound 4; then compound 1.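

In this assay, the dimethylamino group places its compound between the two other 3-substituted phenyl compounds: dimethylamino in place of methyl gives a number 11 percentage points higher from compound 2 to compound 4 (beyond the scatter), while dimethylamino in place of chloro gives a number 14 percentage points lower from compound 1 to compound 4 (beyond the scatter). The 4-methoxyphenyl group keeps the lowest number of the four, and 3-(dimethylamino)phenyl in its place gives a number 21.8 percentage points higher from compound 3 to compound 4 (beyond the scatter), a change that alters both the group and where it sits on the phenyl. Nothing measured here accounts for these differences.

The compounds shown leave open whether the low number of compound 3 belongs to the methoxy group or to its place on the phenyl. A 3-methoxyphenyl or a 4-(dimethylamino)phenyl group on the same aromatic carbon would separate the two.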